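From a Butyl Amide to a Methoxypyridinyl Amide

The compounds below may be only part of what the source reports. "The series", "measured", "known", "first", "only" and "open" are said of these compounds alone.

Of the compounds shown here, three built on one shared core have been tested in a functional assay on the whole organism for inhibition, with Rattus norvegicus as the target, read by paw edema, at a dose of 100 mg/kg by the oral route; on this read-out higher numbers stand for more inhibition at the one dose given (going by the name of the read-out) and lower numbers for less inhibition. Compound 1 `CCCCNC(=O)c1c(O)c2cccnc2n(-c2ccccc2)c1=O` gives 12.8% and stands lowest of the three numbers. Compound 2 `O=C(Nc1ccncc1)c1c(O)c2cccnc2n(-c2ccccc2)c1=O` gives 34.9%, and compound 3 `Cc1cnccc1NC(=O)c1c(O)c2cccnc2n(-c2ccccc2)c1=O` gives 26.9%. Two measured steps start from the butyl amide and swap that chain for an aromatic ring on the amide-type nitrogen: a number 22.1 percentage points higher from compound 1 to compound 2 (beyond the scatter) and a number 14.1 percentage points higher from compound 1 to compound 3 (beyond the scatter). Between the two aromatic amides the step lies within the scatter: a number 8 percentage points lower from compound 2 to compound 3 (within the scatter).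

Compound 4 `COc1ccc(NC(=O)c2c(O)c3cccnc3n(-c3ccccc3)c2=O)cn1` has not yet been measured in this assay. It differs from compound 1 in one place: 6-methoxypyridin-3-yl in place of butyl on an amide-type nitrogen. Both measured steps that replace the butyl with an aromatic ring raised the read-out beyond the scatter by modest amounts, so a modest rise is expected here as well, with the step of a number 15.2 percentage points higher from compound 1 to compound 4 (beyond the scatter) estimated. Compound 4 is therefore expected to give about 28%, within a range from 12% to 45%.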

Compound 4, a percentage reported as inhibition, in the whole organism at one dose (the size of the read-out at that dose, not a potency): 13.1%
Compound 4: the middle estimate sits 14.9 percentage points above what was measured, and the stated range covers the measured number.
By their numbers in this assay, from the lowest: compounds 1 and 4 (each within the scatter of the next); then compounds 3 and 2 (each within the scatter of the next).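

An aromatic ring on the amide-type nitrogen does not by itself raise the read-out: in this assay, 6-methoxypyridin-3-yl in place of butyl gives a number 0.3 percentage points higher from compound 1 to compound 4 (within the scatter). The identity of the ring matters, with a number 13.8 percentage points lower from compound 3 to compound 4 (beyond the scatter) and a number 21.8 percentage points lower from compound 2 to compound 4 (beyond the scatter), so the rise seen with pyridin-4-yl and 3-methylpyridin-4-yl does not extend to this ring. No measurement on hand gives a reason for this difference.

From the compounds shown here alone, it remains open whether the lower number goes with the methoxy group or with a pyridin-3-yl ring in place of a pyridin-4-yl ring, as 6-methoxypyridin-3-yl differs from pyridin-4-yl in both. Also open, going by these compounds, is how a plain pyridin-3-yl, a phenyl ring or a longer chain would read on the same amide-type nitrogen.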